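Replacing 1,3-thiazol-5-yl with 1-methyl-1H-pyrazol-5-yl

A few compounds are considered here, and "the series" means these few. Any claim that something is new, unique, unknown or untested is made for them only; others in the source may bear on it.

In a functional assay on MKN-1 cells (Homo sapiens) for inhibition, read by colorimetric assay and sulforhodamine B assay, with a stated time of 48 h (a higher number here means a weaker inhibitor of growth, a lower number a stronger inhibitor of growth), three amides built on one shared core have been measured. Compound 1 `CCCCCCCCCCCC[C@@H](O)[C@H]1CC[C@H]([C@H](O)CCCCCCCCCCNC(=O)c2cccs2)O1` gives 1820 nM. Compound 2 `CCCCCCCCCCCC[C@@H](O)[C@H]1CC[C@H]([C@H](O)CCCCCCCCCCNC(=O)c2ccoc2)O1` gives 100000 nM. Compound 3 `CCCCCCCCCCCC[C@@H](O)[C@H]1CC[C@H]([C@H](O)CCCCCCCCCCNC(=O)c2cncs2)O1` gives 100000 nM, level with compound 2, and together they hold the highest number of the three.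

Compound 4 `CCCCCCCCCCCC[C@@H](O)[C@H]1CC[C@H]([C@H](O)CCCCCCCCCCNC(=O)c2ccnn2C)O1` departs from compound 3 in one group: 1-methyl-1H-pyrazol-5-yl in place of 1,3-thiazol-5-yl on a carbonyl carbon. It carries 1-methyl-1H-pyrazol-5-yl in place of 1,3-thiazol-5-yl on a carbonyl carbon.

The closest evidence comes from replacements at that same carbonyl carbon. Furan-3-yl in place of thiophen-2-yl gave a 55-fold higher number from compound 1 to compound 2 (1.74 log units; beyond the scatter), and 1,3-thiazol-5-yl in place of thiophen-2-yl gave a 55-fold higher number from compound 1 to compound 3 (1.74 log units; beyond the scatter). Exchanging the two replacements gave no change at the digits printed from compound 2 to compound 3 (within the scatter). Only compound 1, with thiophen-2-yl, stands apart, and compound 4 lacks that group. No step beyond the scatter is therefore expected, although three compounds make a thin basis and a lower number remains possible. The expected step is a 1.4-fold lower number from compound 3 to compound 4 (0.15 log units; within the scatter). For compound 4 the estimate is 70000 nM, with an expected range from 6000 nM to 100000 nM.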

Compound 4, concentration for 50% growth inhibition: 43700 nM
Compound 4: the middle estimate sits 1.6-fold (0.20 log units) above what was measured, within the range that was stated.
By their numbers in this assay, from the lowest: compound 1; then compound 4; then compounds 2 and 3 (each within the scatter of the next).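

Going by these compounds alone, at the carbonyl carbon, 1-methyl-1H-pyrazol-5-yl brings the first step beyond the scatter among the groups that replace thiophen-2-yl, with a 2.3-fold lower number from compound 3 to compound 4 (0.36 log units; beyond the scatter) and a 2.3-fold lower number from compound 2 to compound 4 (0.36 log units; beyond the scatter) in this assay, so the earlier shared level does not hold for every replacement. Thiophen-2-yl still stands apart, with a 24-fold higher number from compound 1 to compound 4 (1.38 log units; beyond the scatter), and compound 1 keeps the lowest number of the four. Nothing measured here accounts for these differences.

Going by these compounds, whether the step to compound 4 belongs to the ring or to its methyl group stays open, and the unmethylated 1H-pyrazol-5-yl would separate the two. Also open, on these data alone, is how thiophen-3-yl, phenyl or a chlorine-bearing thiophen-2-yl would stand against compound 1 at this carbonyl carbon.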